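A few compounds are considered here, and "the series" means these few. Any claim that something is new, unique, unknown or untested is made for them only; others in the source may bear on it.

Compound 2 `Cc1nc(-c2ccccc2F)c(C(=O)N2CCN(c3cc(Cl)cc(Cl)c3)CC2)o1` gives 319 nM in a functional assay on HCT-116 cells (Homo sapiens) for inhibition, read by MTT assay, with a stated time of 72 h (on this read-out lower numbers stand for stronger inhibition and higher numbers for weaker inhibition), the larger of the two numbers shown, though the gap to compound 1 `COc1cc(OC)cc(N2CCN(C(=O)c3oc(C)nc3-c3cccc(F)c3)CC2)c1`, which gives 216 nM in this assay, lies within the scatter. Compound 3 `Cc1nc(-c2cccc(F)c2)c(C(=O)N2CCN(c3cc(Cl)cc(Cl)c3)CC2)o1` has not yet been measured. It differs from compound 2 in one place: 3-fluorophenyl in place of 2-fluorophenyl on an aromatic carbon. Going by the values given here, no step between measured compounds isolates this change. In this assay the expected step is small, a 1.2-fold lower number from compound 2 to compound 3 (0.09 log units; within the scatter), not beyond the scatter. Compound 3 is therefore estimated at 260 nM, within 120 nM to 560 nM.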

Compound 3, half-maximal inhibitory concentration: 366 nM
Compound 3: middle estimate off by 1.4-fold (0.15 log units), on the low side, within the range that was stated.
By their numbers in this assay, from the lowest: compounds 1, 2 and 3 (each within the scatter of the next).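

In this assay, 3-fluorophenyl in place of 2-fluorophenyl on this aromatic carbon gives a 1.1-fold higher number from compound 2 to compound 3 (0.06 log units; within the scatter), so the two fluorophenyl groups cannot be told apart here. With 3-fluorophenyl held constant, 3,5-dichlorophenyl in place of 3,5-dimethoxyphenyl on the ring amine nitrogen gives a 1.7-fold higher number from compound 1 to compound 3 (0.23 log units; within the scatter), so these two groups cannot be told apart either. No measurement bears on why these groups give such similar numbers. On these data alone, it remains open whether a phenyl without fluorine, or one carrying an amine or a carboxylic acid, would give a step beyond the scatter at this position.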